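Replacing an amino side chain on a shared core

The source may report more compounds than this note shows. Statements on the series, on what has been measured and on what is new or still open speak of the compounds shown alone.

Measured so far in a physicochemical assay for solubility, in phosphate buffer, with a stated time of 18 h, at pH 7.4; a lower number here means a less soluble compound, a higher number a more soluble compound
Compound 1 (`Nc1nc(-c2ccccc2)nn1-c1ncnc2cc(Cl)ccc12`) value 300 nM
Compound 2 (`CCOC(=O)CNc1nc(-n2nc(-c3ccccn3)nc2N)c2cc(OC)c(OC)cc2n1`) value 48000 nM

Of these two numbers, compound 2 stands highest, and compound 1 sits lower by a margin well beyond the scatter. Compound 3 (`CCN(CC)c1nc(-n2nc(-c3ccccn3)nc2N)c2cc(OC)c(OC)cc2n1`) has not yet been measured. It keeps the core of compound 2 but carries diethylamino in place of ((ethoxycarbonyl)methyl)amino on an aromatic carbon, between two ring nitrogen atoms (diethylamino in place of ((ethoxycarbonyl)methyl)amino on an aromatic carbon). Among the compounds with values here, no measured pair differs in only one place, so this change has no direct precedent here. With compound 2 at 48000 nM at the top of what has been seen and compound 1 at 300 nM far under it, a fall is the likelier direction, though the evidence for it is thin. The step expected in this assay is a 3.2-fold lower number from compound 2 to compound 3 (0.51 log units; beyond the scatter) and would be a modest fall, only just beyond the scatter. Compound 3 is estimated at 15000 nM with a range of 3000 nM to 50000 nM as the expected bounds.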

Compound 3, solubility: 6000 nM
Estimate against measurement, compound 3: 2.5-fold (0.40 log units) above, and the stated range covers the measured number.
By their numbers in this assay, from the lowest: compound 1; then compound 3; then compound 2.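

Within the data shown here, the first pair on the shared core that differs in one place gives an 8.0-fold lower number from compound 2 to compound 3 (0.90 log units; beyond the scatter) in this assay when diethylamino takes the place of ((ethoxycarbonyl)methyl)amino. This shows that the group on this aromatic carbon, between two ring nitrogen atoms, can shift the read-out by a margin beyond the scatter, even though the rest of the structure stays the same. Among these compounds, the single change removes the hydrogen-bond donor, the carbonyl and the oxygen atoms together, and nothing at hand separates these features or explains the fall.

It remains open which part of the departing group accounts for the difference: a plain ethylamino group would keep the hydrogen-bond donor without the ethoxycarbonyl, whereas a carboxylic acid on the same methylamino chain would keep the carbonyl and drop the ethyl. Also open, as far as these compounds go, is how a cyclic amine such as morpholine, or a longer chain ending in a dimethylamino group, would read at this position, and whether either would fall on the side of compound 2 or of compound 3.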